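A few compounds are considered here, and "the series" means these few. Any claim that something is new, unique, unknown or untested is made for them only; others in the source may bear on it.

In an ADME assay on HOS cells (Homo sapiens) for cytotoxicity, read by luminescence and ATP content, with a stated time of 48 h (a lower number here means that less compound is tolerated, a higher number that more compound is tolerated), compound 1 `Nc1c(C(=O)NCc2ccc(F)cc2F)c(=O)n(O)c2ncc(CCCCCCOCc3ccccc3)cc12` gives 14400 nM. Compound 2 `CC(C)NC(=O)/C=C/c1cnc2c(c1)c(N)c(C(=O)NCc1ccc(F)cc1F)c(=O)n2O` gives > 250000 nM, which is a limit of the assay and not a number. Among the compounds with values here, compound 2 therefore has no exact reading, and no measured pair here differs in only one place.

Compound 3 `COC(=O)CCc1cnc2c(c1)c(N)c(C(=O)NCc1ccc(F)cc1F)c(=O)n2O` is reached from compound 2 by one change: 2-(methoxycarbonyl)ethyl in place of 2-(isopropylcarbamoyl)ethenyl on an aromatic carbon. The rest of the structure stays the same, so the expectation leans mainly on compound 2, whose reading of > 250000 nM is a limit. Compound 1, at 14400 nM, has a different side chain and offers only a loose guide to how far the number could fall.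

The expected result in this assay is little or no change beyond the usual scatter, with any move more likely toward a lower number. The estimated change is an at least 1.2-fold lower number from compound 2 to compound 3 (0.09 log units; that floor lies within the scatter). For compound 3, the expected value is 200000 nM, with an estimated range of 80000 nM to 300000 nM.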

Compound 3, half-maximal cytotoxic concentration: > 250000 nM
Compound 3 gave a limit, no number (the forecaster's own chance of this, stated with the estimate: 50%); middle value at least 1.2-fold (0.09 log units) away from the limit.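

In this assay compound 3 gives > 250000 nM, a limit of the assay and not a number, so this position now has a second side chain that reaches the limit, one with no amide hydrogen and no carbon-carbon double bond. The step between compound 2 and compound 3 cannot be read, because both values are limits: the limit of > 250000 nM in this assay, at which 2 of the 3 values shown sit. The readable comparison is with the long chain of compound 1: methoxycarbonyl in place of 4-(benzyloxy)butyl on a saturated chain carbon, two bonds along the chain from an aromatic carbon, gives an at least 17-fold higher number from compound 1 to compound 3 (1.23 log units; beyond the scatter), a large step beyond the scatter.

The compounds shown leave open how much of that step belongs to the length of the chain and how much to its benzyl ether end, which a plain hexyl chain or a shorter benzyloxy chain at this position could help separate. They also leave open whether a carboxylic acid or an amine at the end of the short chain would stay at the limit or give an exact number.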